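The compounds below may be only part of what the source reports. "The series", "measured", "known", "first", "only" and "open" are said of these compounds alone.

Compound 1 `CC(C)C[C@H](N)C(=O)NS(=O)(=O)OC[C@H]1OC[C@@H](n2cnc3c(N)ncnc32)[C@H](O)[C@@H]1O`: 1000 nM
Compound 2 `Nc1ncnc2c1ncn2[C@@H]1O[C@H](COS(=O)(=O)NC(=O)[C@@H]2CCN2)[C@@H](O)[C@H]1O`: 600 nM
Compound 3 `CC(C)C[C@H](N)C(=O)NS(=O)(=O)OC[C@H]1OC[C@@H](n2cnc3c(N)ncnc32)C[C@@H]1O`: 6800 nM

In a functional assay on PBMC cells (Homo sapiens) for inhibition (on this read-out lower numbers stand for stronger inhibition and higher numbers for weaker inhibition), compound 1 gives 1000 nM, the second highest of the three numbers. Compound 2 gives 600 nM, a gap from compound 1 that stays within the usual scatter of repeated measurements, so the two cannot be told apart. Going by the values given here, compound 3 gives 6800 nM; the step of a 6.8-fold higher number from compound 1 to compound 3 (0.83 log units; beyond the scatter) comes from hydrogen in place of hydroxy on a saturated ring carbon and is the only step among the measured compounds.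

Compound 4 `Nc1ncnc2c1ncn2[C@@H]1CO[C@H](COS(=O)(=O)NC(=O)[C@@H]2CCCN2)[C@@H](O)[C@H]1O` has not been measured. It differs from compound 1 by pyrrolidin-2-yl in place of 1-amino-3-methylbutyl on a carbonyl carbon. Among the compounds with values here, no measured step touches this part of the molecule: the step of a 6.8-fold higher number from compound 1 to compound 3 (0.83 log units; beyond the scatter) alters the ring instead, so it does not bear on the change. Compound 2 also carries a ring on the carbonyl carbon, though on another core, and its number sits within the scatter of compound 1, which hints that such a swap need not cost much. Within the data shown here, with no matched step, compound 4 is expected near 1000 nM, between 300 nM and 3500 nM. The expected step of no change at the digits printed from compound 1 to compound 4 (within the scatter) therefore stays within the scatter.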

Compound 4, half-maximal inhibitory concentration: 750 nM
Compound 4: middle estimate off by 1.3-fold (0.12 log units), on the high side; measured number inside the range.
By their numbers in this assay, from the lowest: compounds 2, 4 and 1 (each within the scatter of the next); then compound 3.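

In this assay, replacing the open-chain 1-amino-3-methylbutyl with the ring-closed pyrrolidin-2-yl on the carbonyl carbon gives a 1.3-fold lower number from compound 1 to compound 4 (0.12 log units; within the scatter). Going by these compounds alone, this is the first matched step at this position, and it shows that on the core of compound 1, an open chain and this five-membered ring cannot be told apart in this read-out. No supporting data are available to explain this result.

As far as these compounds go, both groups seen at this position on this core carry an amine nitrogen, so it remains open whether a group without one, such as a plain isobutyl chain or a carboxylic acid, would give a similar number. Also open, from the compounds shown here alone, is whether replacing hydroxy with hydrogen on the saturated ring carbon would have a similar effect with pyrrolidin-2-yl in place.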